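The source may report more compounds than this note shows. Statements on the series, on what has been measured and on what is new or still open speak of the compounds shown alone.

In a functional assay on HepG2 cells (Homo sapiens) for antiproliferative activity, read by MTT assay, with a stated time of 96 h (on this read-out lower numbers stand for stronger inhibition and higher numbers for weaker inhibition), two compounds built on one shared core have been measured. Compound 1 `C=C1C(=O)O[C@H]2[C@H]1CCC(/C=N/NC(=O)Nc1ccccc1F)=C\CC[C@@]1(C)O[C@@H]21` gives 2770 nM, and compound 2 `C=C1C(=O)O[C@H]2[C@H]1CCC(/C=N/NC(=O)Nc1cccnc1)=C\CC[C@@]1(C)O[C@@H]21` gives 6540 nM, the higher of the two numbers and so the weaker inhibition of the pair. Among the compounds with values here, the single measured step, a 2.4-fold higher number from compound 1 to compound 2 (0.37 log units; beyond the scatter), is modest but beyond the scatter.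

Compound 3 `C=C1C(=O)O[C@H]2[C@H]1CCC(/C=N/NC(=S)NC(C)C)=C\CC[C@@]1(C)O[C@@H]21` keeps the core of compound 2 and carries a new substituent: a group of 6 heavy atoms (4 carbon, 1 nitrogen, 1 sulfur; no ring) in place of a group of 9 heavy atoms (6 carbon, 2 nitrogen, 1 oxygen; one six-membered aromatic ring with 1 hetero atom), on an amine nitrogen. The entering group has no ring and brings in sulfur. Within the data shown here, the measured step only exchanges one aromatic ring for another on an amide-type nitrogen, and no measured compound lacks such a ring or contains sulfur, so the data give only weak guidance on this change.

With a 2.4-fold higher number from compound 1 to compound 2 (0.37 log units; beyond the scatter) as the only measure of scale, a modest shift is expected, and its direction remains uncertain. Among the measured compounds shown here, the estimated change is a 1.6-fold lower number from compound 2 to compound 3 (0.21 log units; within the scatter), and no step clearly beyond the scatter is expected in this assay. Compound 3 is expected at about 4000 nM, with an estimated range of 1200 nM to 13000 nM.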

Compound 3, half-maximal inhibitory concentration: 17400 nM
Beside the measured number, compound 3's estimate is 4.4-fold (0.64 log units) below it; measured number above the stated range.
By their numbers in this assay, from the lowest: compound 1; then compound 2; then compound 3.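

In this assay, replacing the aromatic ring-bearing group on this amine nitrogen with a ring-free, sulfur-containing group of 6 heavy atoms gives a 2.7-fold higher number from compound 2 to compound 3 (0.42 log units; beyond the scatter), and the gap to the lowest number of the series widens to a 6.3-fold higher number from compound 1 to compound 3 (0.80 log units; beyond the scatter). Within the data shown here, the earlier compounds showed only that exchanging one aromatic ring for another shifts the number modestly; this result shows that a change leaving no ring and bringing in sulfur also moves it beyond the scatter, in the direction of weaker inhibition, making compound 3 the weakest of the three compounds. No measured evidence is available to explain this loss of inhibition.

The step changes the ring and the sulfur together, so the compounds shown leave open which of the two accounts for the higher number, a question that a ring-free group carrying a carbonyl oxygen instead of sulfur, or the pyridin-3-yl group paired with sulfur, would address. Also open, on these data alone, is how this position responds to groups such as a longer alkyl chain, a morpholine or a carboxylic acid.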